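The source may report more compounds than this note shows. Statements on the series, on what has been measured and on what is new or still open speak of the compounds shown alone.

The series rests on a shared core whose members were assayed in a functional assay on UACC-62 cells (Homo sapiens) for cytotoxicity, read by sulforhodamine B assay, with a stated time of 48 h, tested at 1 uM; on this read-out lower numbers stand for a stronger effect and higher numbers for a weaker effect at the one concentration tested. Compound 1 `COc1cc(C)cc(-c2c(-c3ccnc(-c4ccc(C(C)=O)cc4)c3)cnn2CC#N)c1` gives 25% in this assay. Compound 2 `COc1cc(C)cc(-c2nn(CC#N)cc2-c2ccc(-c3cccc(C(C)=O)c3)nc2)c1` gives 38% in this assay, and compound 3 `Cc1cc(O)cc(-c2nn(CC#N)cc2-c2ccnc(-c3ccc(Oc4ccccc4)cc3)c2)c1` gives 33% in this assay. Among the three numbers, compound 1 carries the lowest; the number for compound 3 lies within the usual scatter of it, while the number for compound 2 lies beyond that scatter. The account now turns to compound 4 `COc1cc(C)cc(-c2c(-c3ccnc(-c4ccc(N(C)C)cc4)c3)cnn2CC#N)c1`, which has not yet been measured in this assay. Its structure differs from compound 1 in one place: dimethylamino in place of acetyl on an aromatic carbon. Among the measured compounds shown here, no pair of measured compounds differs by that change or by any single change, so there is no measured step to lean on. The replacement keeps the same count of heavy atoms and the same count of hydrogen-bond acceptors at that position, and on that basis only a modest step is expected from compound 1 to compound 4 in this assay, a number 11 percentage points higher from compound 1 to compound 4 (beyond the scatter), leaning toward a somewhat weaker effect. Compound 4 is accordingly estimated at 36% in this assay, with a range from 15% to 62%.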

Compound 4, a percentage reported as activity, at one concentration (the size of the read-out at that concentration, not a potency): 18%
The estimate for compound 4 lay 18 percentage points above the measured number; measured number inside the range.
By their numbers in this assay, from the lowest: compounds 4, 1, 3 and 2 (each within the scatter of the next, the first and the last beyond it).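

Among the compounds shown here, with dimethylamino in place of acetyl on an aromatic carbon para to a large group, this assay gives a number 7 percentage points lower from compound 1 to compound 4 (within the scatter), and this is the first single change that can be read directly. At this position, the difference between 4-acetylphenyl and 4-(dimethylamino)phenyl therefore does not separate the two compounds at the one concentration tested, so the carbonyl of the acetyl group is not required to hold the read-out at this level. No measurement shown here accounts for this result.

The compounds shown leave open whether other groups on this aromatic carbon, such as a carboxylic acid, a primary amine or a longer chain, would also stay within the scatter of compound 1 or would move the read-out beyond it. They also leave open whether the same exchange would read alike on another member of the series, and how the two compounds would compare at other concentrations, since a single concentration gives no measure of potency.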